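The source may hold more compounds than are shown below. What is called first, only, known or untested is meant among the compounds shown, and "the series" means these compounds.

Measured so far:

Compound 1, `CCOc1cc(=O)oc2cc(OCc3cccc(F)c3)ccc12`, gives 263 nM in an assay on isolated protein (strain Sprague-Dawley) for inhibition of Amine oxidase [flavin-containing] B (Rattus norvegicus), read by spectrophotometry, with a stated time of 5 min; on this read-out lower numbers stand for stronger inhibition and higher numbers for weaker inhibition.
Compound 2, `CCCOc1cc(=O)oc2cc(OCc3cccc(F)c3)ccc12`, gives 407 nM in this assay.
Compound 3, `CCOc1cc(=O)oc2cc(OCc3cccc(Cl)c3)ccc12`, gives 115 nM in this assay.

The three compounds share one core and differ only in two side groups. The first difference, (methyl in place of hydrogen on a saturated chain carbon, two bonds along the chain from an oxygen on an aromatic ring), turns the ethoxy of compound 1 into the propoxy of compound 2, and the step it makes is a 1.5-fold higher number from compound 1 to compound 2 (0.19 log units; within the scatter). The second difference, (chloro in place of fluoro on an aromatic carbon), turns the 3-fluorophenyl of compound 1 into the 3-chlorophenyl of compound 3, and here the step is a 2.3-fold lower number from compound 1 to compound 3 (0.36 log units; beyond the scatter). Compound 3 therefore stands at the lowest number of the three, with compound 1 nearest and compound 2 furthest.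

Compound 4, `CC(C)Oc1cc(=O)oc2cc(OCc3cccc(Cl)c3)ccc12`, has not been measured. It differs from compound 3 by methyl in place of hydrogen on a saturated chain carbon bound to an oxygen on an aromatic ring and a saturated chain carbon, that is ethoxy to isopropoxy. Going by the values given here, this is the same kind of change as the one from compound 1 to compound 2, but not the same: there the added methyl sits on a saturated chain carbon two bonds along the chain from an oxygen on an aromatic ring, whereas here it sits on a saturated chain carbon bound to an oxygen on an aromatic ring and a saturated chain carbon. The two cores differ by chloro in place of fluoro on an aromatic carbon. Among the compounds with values here, because the one measured step of this kind, a 1.5-fold higher number from compound 1 to compound 2 (0.19 log units; within the scatter), lay within the scatter, the step from compound 3 to compound 4 is expected to be small as well, about a 1.5-fold higher number from compound 3 to compound 4 (0.17 log units; within the scatter). Compound 4 is thus estimated at 170 nM in this assay, between 70 nM and 400 nM.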

Compound 4, half-maximal inhibitory concentration: 24500 nM
Compound 4: the middle estimate sits 140-fold (2.16 log units) below what was measured, outside the stated range (above it).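

In this assay, one added methyl turns the ethoxy of compound 3 into an isopropoxy, and inhibition becomes far weaker, with a 210-fold higher number from compound 3 to compound 4 (2.33 log units; beyond the scatter). Set beside the earlier methyl addition, this shows that a small step on one compound gave no safe guide to the step on the other, and that a single added methyl can matter greatly in this series: the same change on two cores in this assay, a 1.5-fold higher number (0.19 log units; within the scatter) from compound 1 to compound 2 and a 210-fold higher number (2.33 log units; beyond the scatter) from compound 3 to compound 4, 140-fold (2.14 log units) apart, beyond the scatter of two such steps. It does not show that the chloro in place of fluoro on the core is what separates the two steps, since the methyl also sits in a different place: on a saturated chain carbon two bonds along the chain from the oxygen in compound 2, and on the saturated chain carbon bound to that oxygen in compound 4.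

Still open, from the compounds shown here alone, is how an isopropoxy reads on the core of compound 1 and how a propoxy reads on the core of compound 3, the two pairings that would separate the place of the methyl from the change of core. Also open, going by these compounds, is how a longer chain such as butoxy, or a bromo in place of the chloro, would read in this assay.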